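Moving the Bromine on the Benzyl Group of Compound 3

The compounds below may be only part of what the source reports. "The series", "measured", "known", "first", "only" and "open" are said of these compounds alone.

Compound 1, `CCCN(C)C(=O)c1cc2c(Cc3ccccc3)n[nH]c2cc1O`: > 10000 nM
Compound 2, `CN(C(=O)c1cc2c(Cc3ccccc3)n[nH]c2cc1O)c1ccco1`: 2500 nM
Compound 3, `CN(Cc1ccccc1Br)C(=O)c1cc2c(Cc3ccccc3)n[nH]c2cc1O`: 1200 nM

Of the compounds shown here, three sharing one core have been measured in a functional assay on A2780 cells (Homo sapiens) for antiproliferative activity, read by resazurin assay, with a stated time of 72 h; a higher number here means a weaker inhibitor, a lower number a stronger inhibitor. The value of compound 1 is a limit of this assay rather than a number (the limit of > 10000 nM in this assay, at which 1 of the 3 values shown sits). Among the two numbers, compound 3 stands lowest, with compound 2 nearest, a 2.1-fold lower number from compound 2 to compound 3 (0.32 log units; beyond the scatter). Compound 1 to compound 2 gave an at least 4.0-fold lower number from compound 1 to compound 2 (0.60 log units; beyond the scatter), and compound 1 to compound 3 gave an at least 8.3-fold lower number from compound 1 to compound 3 (0.92 log units; beyond the scatter).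

Compound 4, `CN(Cc1ccc(Br)cc1)C(=O)c1cc2c(Cc3ccccc3)n[nH]c2cc1O`, is not yet measured. It differs from compound 3 in one place: 4-bromophenyl in place of 2-bromophenyl on a saturated chain carbon bound to an amide-type nitrogen. For the measured compounds named here, none of the measured steps moves the bromine around the ring; they exchange whole groups on the amide-type nitrogen, so none bears directly on this change. Going by the values given here, with no step to lean on, compound 4 is expected to sit close to compound 3, within the usual scatter, so that no change at the digits printed from compound 3 to compound 4 (within the scatter) is the estimated step. In this assay compound 4 is therefore estimated at 1200 nM, with a range from 400 nM to 3600 nM.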

Compound 4, half-maximal inhibitory concentration: 2800 nM
Beside the measured number, compound 4's estimate is 2.3-fold (0.37 log units) below it, within the range that was stated.
By their numbers in this assay, from the lowest: compound 3; then compounds 2 and 4 (each within the scatter of the next). At a limit, above all of these: compound 1.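

In this assay, for the compounds shown here, the placement of the bromine on the benzyl group matters even though the atoms stay the same: going from 2-bromobenzyl to 4-bromobenzyl gave a 2.3-fold higher number from compound 3 to compound 4 (0.37 log units; beyond the scatter), the first measured step that changes only where one atom sits on the ring. A bromobenzyl group on the amide-type nitrogen therefore does not in itself separate a compound from the furan-2-yl of compound 2, since 4-bromobenzyl in place of furan-2-yl gave a 1.1-fold higher number from compound 2 to compound 4 (0.05 log units; within the scatter), whereas 2-bromobenzyl in place of furan-2-yl gave a 2.1-fold lower number from compound 2 to compound 3 (0.32 log units; beyond the scatter) and so kept a small margin. The 4-bromophenyl in place of ethyl still gave an at least 3.5-fold lower number from compound 1 to compound 4 (0.55 log units; beyond the scatter), so the gain over the propyl amide of compound 1 survives the move, although the value of compound 1 is a limit and not a number: the limit of > 10000 nM in this assay, at which 1 of the 4 values shown sits.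

Nothing shown accounts for the difference between the two bromine placements. From the compounds shown here alone, it also remains open whether an unsubstituted benzyl group, or chlorine or a methoxy group in place of the bromine, would match compound 3 or fall back towards compound 4.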